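Vinyl in Place of 2-Fluorophenyl on the Shared Core

A few compounds are considered here, and "the series" means these few. Any claim that something is new, unique, unknown or untested is made for them only; others in the source may bear on it.

Compound 1 `O=C(Nc1cc(F)ccc1F)c1cc(=O)[nH]c2cc(Br)ccc12` and compound 2 `O=C(Nc1cccc(F)c1)c1cc(=O)[nH]c2cc(-c3ccccc3F)ccc12` share one core. In a functional assay on KYSE-70 cells for antiproliferative activity against KYSE-70 cell line (Homo sapiens), read by MTT assay, with a stated time of 72 h (a lower number here means a stronger inhibitor, a higher number a weaker inhibitor), compound 1 gives only a limit, > 20000 nM. Compound 2 likewise gives only a limit in this assay, > 20000 nM. Compound 2 therefore stands at the limit of > 20000 nM in this assay, at which 2 of the 2 values shown sit. Compound 3 `C=Cc1ccc2c(C(=O)Nc3cccc(F)c3)cc(=O)[nH]c2c1` differs from compound 2 by vinyl in place of 2-fluorophenyl on an aromatic carbon. Within the data shown here, with both known values at the limit, no measured step exists to guide the change. Compound 3 is expected to give an estimated 20000 nM, between 5000 nM and 60000 nM. The step of a number no higher from compound 2 to compound 3 (the limit leaves the size open) is expected to be none beyond the scatter.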

Compound 3, half-maximal inhibitory concentration: 9700 nM
Estimate against measurement, compound 3: 2.1-fold (0.31 log units) above; the range from low to high includes it.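

In this assay, vinyl in place of 2-fluorophenyl gives an at least 2.0-fold lower number from compound 2 to compound 3 (0.31 log units; beyond the scatter), so the group on this aromatic carbon can bring the value off the limit. From the compounds shown here alone, the full size of this step stays open, since compound 2 gives only a limit: the limit of > 20000 nM in this assay, at which 2 of the 3 values shown sit. Still open, going by these compounds, is whether an ethyl chain, an amine or a carboxylic acid on this aromatic carbon would lower the value further. The compounds shown also do not separate the effect of the vinyl double bond from that of removing the 2-fluorophenyl ring.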